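This account rests on a few compounds, and the source may have more. Where it says the series, first, only, none or still open, it means among the compounds named here.

Compound 1 `OC[C@H]1O[C@@H](n2cnc3c(NCc4cccc(F)c4)ncnc32)[C@H](O)[C@@H]1O`, compound 2 `COc1cccc(CNc2ncnc3c2ncn3[C@@H]2O[C@H](CO)[C@@H](O)[C@H]2O)c1OC` and compound 3 `COc1cc(CNc2ncnc3c2ncn3[C@@H]2O[C@H](CO)[C@@H](O)[C@H]2O)cc(OC)c1` share one core and were examined in a functional assay on HOS cells (Homo sapiens) for antiproliferative activity, with a stated time of 72 h; a higher number here means a weaker inhibitor, a lower number a stronger inhibitor. Here compound 1 gives > 166000 nM, which is a limit and not a number. Compound 2 gives > 166000 nM, which is also a limit. For compound 3 the entry reads "not determined" (no result reported), so compound 3 has no number of its own, and the nearest reference is the limit of > 166000 nM in this assay, at which 2 of the 3 values shown sit.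

Compound 4 `Cc1cccc(CNc2ncnc3c2ncn3[C@@H]2O[C@H](CO)[C@@H](O)[C@H]2O)c1O` differs from compound 3 in one group: 2-hydroxy-3-methylphenyl in place of 3,5-dimethoxyphenyl on a saturated chain carbon bound to a nitrogen on an aromatic ring. Among the measured compounds shown here, the only measured step, a step that the two limits leave unreadable from compound 1 to compound 2, also exchanges the aryl group in this place, but it has no readable size. No particular size or direction of step can therefore be expected in this assay, and compound 3 offers no number to start from. The expectation rests instead on compound 2, whose > 166000 nM is a limit. Compound 4 is expected near that limit, at an estimated 100000 nM, with an estimated range of 10000 nM to 300000 nM.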

Compound 4, half-maximal inhibitory concentration: > 166000 nM
Compound 4 was reported as a limit; the forecaster's own chance of this, stated with the estimate: 65%; at least 1.6-fold (0.22 log units) between middle value and limit.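

Compound 4 stands at a limit, as compound 1 and compound 2 do, so no step among these three can be read: the limit of > 166000 nM in this assay, at which 3 of the 4 values shown sit.
Whether in this assay any aryl group in this place on the shared core gives a number rather than a limit stays open with the compounds shown.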